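Swapping the ring on the thiocarbonyl of a chromone dithiocarbamate

The source may hold more compounds than are shown below. What is called first, only, known or untested is meant among the compounds shown, and "the series" means these compounds.

Of the compounds shown here, three sharing a chromone dithiocarbamate core have been tested in a functional assay on HEp-2 cells (Homo sapiens) for antiproliferative activity, read by MTT assay, with a stated time of 72 h; a higher number here means a weaker inhibitor, a lower number a stronger inhibitor. Compound 1 `O=c1cc(CSC(=S)N2CCCCC2)oc2cc(Cl)ccc12` gives 1600 nM. Compound 2 `COc1ccc2occ(CSC(=S)N3CCCC3)c(=O)c2c1` gives 3100 nM. Compound 3 `Cc1ccc2c(=O)c(CSC(=S)N3CCOCC3)coc2c1` gives 4000 nM. The number for compound 2 sits between those of compounds 1 and 3, but all three lie within the usual scatter of one another, so none of them can be called stronger or weaker than the others on this evidence.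

Compound 4 `COc1ccc2occ(CSC(=S)N3CCOCC3)c(=O)c2c1` has not yet been measured. It differs from compound 2 in one place: morpholin-4-yl in place of pyrrolidin-1-yl on a thiocarbonyl carbon. Among the measured compounds, compound 3 carries the same morpholin-4-yl group, though on a core with a methyl rather than a methoxy substituent, and its number in this assay is close to that of compound 2.

Because compound 3 gives 4000 nM with the entering group, and compound 2 gives 3100 nM with the leaving one, the step from compound 2 to compound 4 is expected to be small, likely no more than the scatter, with a slight lean towards a higher number; the expected step is a 1.2-fold higher number from compound 2 to compound 4 (0.06 log units; within the scatter). Compound 4 is expected to give about 3600 nM in this assay, within a range from 1500 nM to 8500 nM.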

Compound 4, half-maximal inhibitory concentration: 4800 nM
Compound 4: middle estimate off by 1.3-fold (0.12 log units), on the low side, and the stated range covers the measured number.
By their numbers in this assay, from the lowest: compounds 1, 2, 3 and 4 (each within the scatter of the next, the first and the last beyond it).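

Among the compounds shown here, compounds 2 and 4 form the first pair here that differs in only one place, so the group on the thiocarbonyl carbon can be read on its own, with the rest of the molecule held constant. In this assay, morpholin-4-yl in place of pyrrolidin-1-yl gives a 1.5-fold higher number from compound 2 to compound 4 (0.19 log units; within the scatter), so this change cannot be told apart from repeat-measurement noise, even though the entering ring has 6 heavy atoms against 5 and 1 hydrogen-bond acceptor against 0. No measured property is available to help interpret this step.

On these data alone, whether any group at this place can move the number beyond the scatter remains open, and a 4-methylpiperazin-1-yl ring or an open-chain diethylamino group on the core of compound 2 would extend the comparison. Also open, as far as these compounds go, is whether the same swap behaves alike on the cores of compound 1 and compound 3, each of which stands here without a partner differing in that one place.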